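The source may hold more compounds than are shown below. What is called first, only, known or untested is meant among the compounds shown, and "the series" means these compounds.

Compound 1 `CC(C)n1c(/C=C2/C(=O)Nc3ccc(Br)cc32)nc2ccccc21` gives 56900 nM in a toxicity assay on MCF-10A cells (Homo sapiens) for cytotoxicity, read by MTT assay, with a stated time of 48 h; on this read-out lower numbers stand for stronger inhibition and higher numbers for weaker inhibition. Compound 2 `CC(C)n1c(/C=C2/C(=O)Nc3ccc(F)cc32)nc2ccccc21` shares the core of compound 1 but carries fluoro in place of bromo. In this assay, going by these compounds, compound 2 reaches only a limit of the assay, > 100000 nM, and not a number, so its exact position remains unknown.

Compound 3 `CC(C)n1c(/C=C2/C(=O)Nc3ccc(Cl)cc32)nc2ccccc21` keeps the same core and differs from compound 2 by one swap: chloro in place of fluoro on an aromatic carbon. Going by the values given here, only one measured step bears on this swap, because an at least 1.7-fold higher number from compound 1 to compound 2 (0.24 log units; that floor lies within the scatter) is the sole change of a group at this place. That step is a floor rather than a full size, and the floor lies within the scatter, so it shows no clear effect of changing this group.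

No step beyond the scatter is therefore expected in this assay, although a value close to compound 1 at 56900 nM seems likely. The expected change is an at least 1.3-fold lower number from compound 2 to compound 3 (0.12 log units; that floor lies within the scatter). For compound 3 the estimated value is 75000 nM, with an expected range from 35000 nM to 150000 nM.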

Compound 3, half-maximal inhibitory concentration: 68800 nM
Compound 3: middle estimate off by 1.1-fold (0.04 log units), on the high side, within the range that was stated.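

In this assay, chloro and bromo on this aromatic carbon can now be compared as two real numbers, and a 1.2-fold higher number from compound 1 to compound 3 (0.08 log units; within the scatter) shows no clear effect of exchanging one of these groups for the other. Going by these compounds, the exchange of fluoro for chloro adds a second view of the same place, an at least 1.4-fold lower number from compound 2 to compound 3 (0.16 log units; that floor lies within the scatter), but this is again only a floor, and it shows no clear effect, while the full size of the step remains unknown. Going by these compounds alone, compound 2 is still the only one of the three compounds without a number, and what it offers is a limit of the assay, not a measured value: the limit of > 100000 nM in this assay, at which 1 of the 3 values shown sits.

On these data alone, whether fluoro truly differs from chloro and bromo at this place remains open, since a floor within the scatter neither confirms nor rules out a larger gap. All three compounds carry a halogen on this carbon, which leaves open what a plain hydrogen, a methoxy group, an amine or a carboxylic acid would do there in this assay.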